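The compounds below may be only part of what the source reports. "The series", "measured", "known", "first", "only" and "open" are said of these compounds alone.

Measured in a functional assay for inhibition, with Homo sapiens as the target; a lower number here means a stronger inhibitor, a higher number a weaker inhibitor:
- compound 1 `COC(C)c1cc(-c2ccccc2)c2ccc(OCc3cccc(C4(O)CCOCC4)c3)cc2c1`: 41 nM
- compound 2 `OC1(c2cccc(COc3ccc4c(-c5ccccc5)cc(-c5nn[nH]n5)cc4c3)c2)CCOCC1`: > 700 nM (a limit)

Compound 2 is known only as a limit of this assay, > 700 nM, and has no exact number. This is the limit of > 700 nM in this assay, at which 1 of the 2 values shown sits.

Compound 3 `Cn1nnnc1-c1cc(-c2ccccc2)c2ccc(OCc3cccc(C4(O)CCOCC4)c3)cc2c1` carries 1-methyl-1H-tetrazol-5-yl in place of 2H-tetrazol-5-yl on an aromatic carbon. Going by the values given here, no measured step tests this exchange directly. The nearest one is an at least 17-fold higher number from compound 1 to compound 2 (1.23 log units; beyond the scatter), a large step that came with the entry of 2H-tetrazol-5-yl in place of 1-methoxyethyl. Compound 3 no longer has that group, so part of that loss is expected to be recovered, though how much is open. The expected change, a moderate to large move to a lower number, is an at least 4.1-fold lower number from compound 2 to compound 3 (0.61 log units; beyond the scatter). For compound 3 the estimated value is 170 nM, with an expected range of 45 nM to 650 nM.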

Compound 3, half-maximal inhibitory concentration: > 67 nM
Compound 3: a limit, no number (the forecaster's own chance of this, stated with the estimate: 15%); the middle value is on the limit's open side.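

In this assay compound 3 is known only as a limit, > 67 nM, so 1-methyl-1H-tetrazol-5-yl gives no exact number at this position: the limit of > 67 nM in this assay, at which 1 of the 3 values shown sits.
Measured against 1-methoxyethyl, the exchange gives an at least 1.6-fold higher number from compound 1 to compound 3 (0.21 log units; that floor lies within the scatter), so this group is not shown to cost anything, unlike 2H-tetrazol-5-yl, where the floor of an at least 17-fold higher number from compound 1 to compound 2 (1.23 log units; beyond the scatter) is already beyond the scatter.
The step between the two tetrazole groups cannot be read, as both of its ends are limits: the limit of > 700 nM in this assay, at which 1 of the 3 values shown sits.

Still open, from the compounds shown here alone, is where the true value of compound 3 lies, and with it whether methylating the tetrazole changes the number at all.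
Also open, going by these compounds, is how a carboxylic acid or a primary amide would read at this position on the shared core.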